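This account rests on a few compounds, and the source may have more. Where it says the series, first, only, none or still open, it means among the compounds named here.

Compound 1, `CC(C)(C)c1ccc(S(=O)(=O)Nc2ccccc2)cc1`, and compound 2, `O=S(=O)(Nc1ccccc1)c1ccc(-c2ccccc2)cc1`, share a small core; in a functional assay on A549 cells (Homo sapiens) for inhibition (on this read-out lower numbers stand for stronger inhibition of growth and higher numbers for weaker inhibition of growth), compound 1 gives 16000 nM and compound 2 gives 17000 nM, a step of a 1.1-fold higher number from compound 1 to compound 2 (0.03 log units; within the scatter) for the change (phenyl in place of tert-butyl on an aromatic carbon). Compound 3, `Cc1cc(C2(c3ccccc3)C(=O)Nc3ccccc32)c(NS(=O)(=O)c2ccc(C(C)(C)C)cc2)cc1O`, carries a larger core; the difference between the two cores is not broken down here. In this assay compound 3 gives 800 nM. Compound 4, `Cc1cc(C2(c3ccccc3)C(=O)Nc3ccccc32)c(NS(=O)(=O)c2ccc(-c3ccccc3)cc2)cc1O`, has not yet been measured; it differs from compound 3 by phenyl in place of tert-butyl on an aromatic carbon, the same change as between compound 1 and compound 2. Because the step of a 1.1-fold higher number from compound 1 to compound 2 (0.03 log units; within the scatter) lay within the scatter, compound 4 is expected to stay close to compound 3, with an estimated step of a 1.1-fold higher number from compound 3 to compound 4 (0.05 log units; within the scatter) in this assay. Compound 4 is therefore expected to give about 900 nM, likely between 450 nM and 1800 nM.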

Compound 4, concentration for 50% growth inhibition: 4000 nM
Compound 4: the middle estimate sits 4.4-fold (0.65 log units) below what was measured, and the stated range ends below it.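

In this assay phenyl in place of tert-butyl on an aromatic carbon gives a 5.0-fold higher number from compound 3 to compound 4 (0.70 log units; beyond the scatter) on the larger core, a weakening of growth inhibition that the small core did not show. The change therefore did not carry over unaltered from one core to the other: the same change on two cores in this assay, a 1.1-fold higher number (0.03 log units; within the scatter) from compound 1 to compound 2 and a 5.0-fold higher number (0.70 log units; beyond the scatter) from compound 3 to compound 4, 4.7-fold (0.67 log units) apart, beyond the scatter of two such steps. This shows that the size of the step depends on the core in these two pairs, but it does not show which part of the larger core is responsible, nor how the change would behave on any further core.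

The compounds shown leave open how an amine, a carboxylic acid or a longer chain in place of tert-butyl would fare on either core. They also leave open whether the gap between the two steps would hold in any other assay.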